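The compounds below may be only part of what the source reports. "The series", "measured", "known", "first", "only" and "open" are said of these compounds alone.

Of the compounds shown here, three that share one core have been tested in an assay on isolated protein for displacement of a labelled ligand from metabotropic glutamate receptor 5 (Homo sapiens), with a stated time of 60 min, tested at 1 uM; a higher number here means more inhibition at the concentration tested (going by the name of the read-out), a lower number less inhibition. Compound 1, `CC1CCN(c2c(S(=O)(=O)c3cc(F)cc(F)c3)cnc3cc(F)ccc23)CC1`, carries a 3,5-difluorophenyl on the sulfonyl sulfur, and compound 1 gives 77%. Compound 2, `CC1CCN(c2c(S(=O)(=O)c3ccc(Cl)cc3)cnc3cc(F)ccc23)CC1`, carries a 4-chlorophenyl in that place, and compound 2 gives 90%. Compound 3, `CC1CCN(c2c(S(=O)(=O)c3ccc(F)c(Cl)c3)cnc3cc(F)ccc23)CC1`, carries a 3-chloro-4-fluorophenyl, and compound 3 gives 94%, the highest of the three numbers, although its gap to compound 2 lies within the usual scatter, so these two cannot be ranked against each other; only the gap to compound 1 is clear.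

The next compound, compound 4, is `CC1CCN(c2c(S(=O)(=O)c3ccc(F)c(F)c3)cnc3cc(F)ccc23)CC1`. It differs from compound 3 in one place: fluoro in place of chloro on an aromatic carbon. Among the measured compounds shown here, two measured steps bear on this swap. The number is a number 17 percentage points higher from compound 1 to compound 3 (beyond the scatter), and it is a number 13 percentage points higher from compound 1 to compound 2 (beyond the scatter); in both, the ring that carries a chloro group scores above the ring that carries only fluoro groups. By contrast the number is a number 4 percentage points higher from compound 2 to compound 3 (within the scatter), where a 3-chloro-4-fluorophenyl replaces a 4-chlorophenyl, so adding a fluoro beside an existing chloro changes little. Taking the chloro away and leaving a ring with only fluoro groups is therefore expected to lower the number modestly, by about a number 10 percentage points lower from compound 3 to compound 4 (within the scatter). Compound 4 is expected to give 84%, within a range from 72% to 94%.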

Compound 4, a percentage reported as inhibition, at one concentration (the size of the read-out at that concentration, not a potency): 94%
The estimate for compound 4 lay 10 percentage points below the measured number; the range from low to high includes it.
By their numbers in this assay, from the lowest: compound 1; then compounds 2, 3 and 4 (each within the scatter of the next).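

Chloro is not needed at this place on the ring: in this assay, fluoro in its place gives no change at the digits printed from compound 3 to compound 4 (within the scatter), so the swap of one halogen for the other on this aromatic carbon leaves the read-out unmoved. The earlier compounds suggested that a ring with only fluoro groups scores lower, but compound 4 goes against that, with a number 4 percentage points higher from compound 2 to compound 4 (within the scatter) and with a number 17 percentage points higher from compound 1 to compound 4 (beyond the scatter), so among these compounds what separates compound 1 from compound 4 is the difference between 3,5-difluorophenyl and 3,4-difluorophenyl, not the presence of chloro. No measurement offered here explains why these two halogens read alike at this place.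

The compounds shown leave open whether a larger or differently built group on the same carbon, such as methoxy, trifluoromethyl or a nitrile, would hold the number as well, or whether a plain hydrogen there would do the same. Compounds 2, 3 and 4 are also read at a single concentration, which gives no potency and so leaves open whether they would still match in a full concentration series.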